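The compounds below may be only part of what the source reports. "The series", "measured", "known", "first", "only" and "open" are said of these compounds alone.

In a functional assay on COLO 205 cells (Homo sapiens) for cytotoxicity, read by MTT assay, with a stated time of 48 h (on this read-out higher numbers stand for weaker inhibition and lower numbers for stronger inhibition), compound 1 `Fc1ccc2nc(-c3ccccc3)nc(Nc3ccccc3)c2c1` gives > 50000 nM as a limit of the assay. Compound 2 `Fc1cccc(-c2nc(Nc3cccc(Cl)c3)c3cc(F)ccc3n2)c1` likewise gives > 50000 nM as a limit and not a number. Among the compounds with values here, both stand at the limit of > 50000 nM in this assay, at which 2 of the 2 values shown sit, and no measured step exists to guide the next one. Compound 3 `Nc1ccc(Nc2nc(-c3cccc(F)c3)nc3ccc(F)cc23)cc1` has 4-aminophenyl in place of 3-chlorophenyl on a nitrogen on an aromatic ring, the change 4-aminophenyl in place of 3-chlorophenyl on a nitrogen on an aromatic ring being the only one. A modest move towards stronger inhibition is expected, with an at least 2.5-fold lower number from compound 2 to compound 3 (0.39 log units; beyond the scatter) as the estimated step, though the reading may stay at the limit. The expected value for compound 3 is 20000 nM with a range from 4000 nM to 50000 nM as estimated.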

Compound 3, half-maximal inhibitory concentration: > 50000 nM
Compound 3 was reported as a limit; the forecaster's own chance of this, stated with the estimate: 50%; middle value at least 2.5-fold (0.39 log units) from the limit.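

In this assay compound 3 gives > 50000 nM, a limit and not a number. Within the data shown here, compound 2 also stands at a limit, and no step between compound 2 and compound 3 can be read. The compounds shown leave open which change to the shared core, if any, would bring a reading inside the range of the assay.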